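The source may report more compounds than this note shows. Statements on the series, on what has been measured and on what is new or still open speak of the compounds shown alone.

Measured compounds so far:

Compound 1, `CC[C@@H]1c2cn[nH]c2C(=O)[C@H](CC)N1S(=O)(=O)c1ccc(Cl)cc1`: 65%
Compound 2, `CC1(C)C(=O)c2[nH]ncc2C(C2CC2)N1S(=O)(=O)c1ccc(C(F)(F)F)cc1`: 67%
Compound 3, `CC(C)[C@H]1C(=O)c2[nH]ncc2[C@@H](C(C)C)N1S(=O)(=O)c1ccc(C(F)(F)F)cc1`: 82%

All three share a core and were tested in an ADME assay on microsomes from liver (Homo sapiens) for metabolic stability, with a stated time of 30 min, tested at 2 uM, in the presence of a further agent that is not named here; a lower number here means that less of the compound is left, a higher number that more of the compound is left. Among the three numbers, compound 2 holds the second highest place. Its nearest neighbour is compound 1, whose value lies within the usual scatter of this assay, so the two cannot be told apart; compound 3 sits furthest away, and that gap lies beyond the scatter.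

Compound 4, `CC1C(=O)c2[nH]ncc2C(C2CC2)N1S(=O)(=O)c1ccc(C(F)(F)F)cc1`, has not yet been measured in this assay. It differs from compound 2 in a single spot: hydrogen in place of methyl on a saturated ring carbon. In words, a hydrogen stands in place of a methyl on a saturated ring carbon.

Going by the values given here, no two measured compounds differ in exactly one place, so there is no measured step of this kind to lean on. The change removes only a single carbon, and the expectation is that this assay will register little movement, most likely none beyond the scatter, with any shift more likely downward than upward.

The value for compound 4 is therefore expected to be about 60%, within a range from 42% to 78%. The step this estimate implies, a number 7 percentage points lower from compound 2 to compound 4 (within the scatter), is expected to stay within the usual scatter.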

Compound 4, percent of the compound remaining: 67%
The estimate for compound 4 lay 7 percentage points below the measured number; the measured number falls inside the stated range.
By their numbers in this assay, from the lowest: compounds 1, 2 and 4 (each within the scatter of the next); then compound 3.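

In this assay, putting a hydrogen in place of one of the two methyl groups on the saturated ring carbon next to the ring nitrogen gives no change at the digits printed from compound 2 to compound 4 (within the scatter), so one methyl and two methyls on this carbon cannot be told apart in this read-out. Going by these compounds alone, this is the first pair that differs in one place only, which lets this position be judged on its own, whereas the earlier compounds differ from each other in several places at once. Nothing available explains why the number holds steady across this change, so the result stands as an observation without a cause.

The compounds shown leave open what happens when the remaining methyl on this carbon is also replaced by hydrogen, since compound 4 still carries one methyl there. They also leave open whether a quite different group at this carbon, such as an amine, a carboxylic acid or a longer chain like butyl, would stay just as close to compound 2 in this assay or move beyond the scatter.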